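The source may report more compounds than this note shows. Statements on the series, on what has been measured and on what is new or still open speak of the compounds shown alone.

Measured compounds:
compound 1 `COc1ccc(-c2cc3c(OC)cc(OC)cc3n(C)c2=O)cc1`, 10000 nM
compound 2 `COc1ccc(-c2cc3c(OC)cc(OC)cc3n(CC(=O)O)c2=O)cc1`, 10000 nM

In a functional assay on MCF7 cells (Homo sapiens) for cytotoxicity, read by colorimetric assay and MTT assay (a lower number here means a stronger inhibitor, a higher number a weaker inhibitor), compound 1 gives 10000 nM. Compound 2 carries a carboxy in place of hydrogen on a saturated chain carbon bound to an aromatic nitrogen, and in this assay compound 2 gives 10000 nM; the step of no change at the digits printed from compound 1 to compound 2 (within the scatter). Compound 2 therefore stands level with compound 1 at the digits shown, its nearest neighbour, with no change beyond the scatter between them.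

Compound 3 `COc1ccc(-c2cc3c(OC)cc(OC)cc3n(CCC#N)c2=O)cc1` is not yet measured. It differs from compound 2 by cyanomethyl in place of carboxy on a saturated chain carbon bound to an aromatic nitrogen. For the measured compounds named here, the only measured step at that place, no change at the digits printed from compound 1 to compound 2 (within the scatter), shows that replacing the hydrogen there with a carboxy left the value unchanged within the scatter. Going by the values given here, no measured compound carries a cyanomethyl or any nitrile, so there is no direct precedent for the group that enters. Among the compounds with values here, on the single step available, a step of no size beyond the scatter is expected for compound 3, no change at the digits printed from compound 2 to compound 3 (within the scatter). Compound 3 is therefore estimated at 10000 nM in this assay, within a range from 4000 nM to 25000 nM.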

Compound 3, half-maximal inhibitory concentration: 10000 nM
Estimate against measurement, compound 3: no gap at the digits printed; the measured number falls inside the stated range.
By their numbers in this assay, from the lowest: compounds 1, 2 and 3 (each within the scatter of the next).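

In this assay, cyanomethyl in place of carboxy on a saturated chain carbon bound to an aromatic nitrogen gives no change at the digits printed from compound 2 to compound 3 (within the scatter), and cyanomethyl in place of hydrogen at that place gives no change at the digits printed from compound 1 to compound 3 (within the scatter). The earlier pair had shown this flat reading for carboxy alone; now a second group, with a triple bond and no hydrogen-bond donor, also stands level with compound 1 at 10000 nM, so two different groups at this place give no step beyond the scatter. No evidence is at hand to explain this flat reading.

The compounds shown leave open whether any other group at this place would depart from that level, for instance an amine, a benzyl group or a chain longer than 2-cyanoethyl. They also leave open whether the same flat reading would hold on a core with a hydroxy group in place of one of its methoxy groups, since all the compounds here share the same core.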